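The source may hold more compounds than are shown below. What is called first, only, known or untested is meant among the compounds shown, and "the series" means these compounds.

Of the compounds shown here, three that share one core have been measured in a functional assay on SK-OV-3 cells (Homo sapiens) for cytotoxicity, read by MTT assay, with a stated time of 72 h; a lower number here means a stronger inhibitor, a higher number a weaker inhibitor. Compound 1, `O=C1C(Nc2ccc(F)cc2)=CC(=O)c2ncncc21`, gives 0.07 ug/mL. Compound 2, `O=C1C(Nc2ccc(I)cc2)=CC(=O)c2ncncc21`, gives 0.04 ug/mL. Compound 3, `O=C1C(Nc2ccc(Br)cc2)=CC(=O)c2ncncc21`, gives 0.02 ug/mL. Among the three numbers, compound 3 has the lowest, but one step is only a 2.0-fold lower number from compound 2 to compound 3 (0.30 log units; within the scatter), so those two cannot be separated, while the other step is a 3.5-fold lower number from compound 1 to compound 3 (0.54 log units; beyond the scatter) and does separate them.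

Compound 4 is `Cc1ccc(NC2=CC(=O)c3ncncc3C2=O)cc1`. It differs from compound 3 in one place: methyl in place of bromo on an aromatic carbon. Among the compounds with values here, no measured step swaps a halogen for a methyl, so nothing directly matches this change. The steps that come nearest all exchange one halogen for another on the same aromatic carbon: a 1.8-fold lower number from compound 1 to compound 2 (0.24 log units; within the scatter), a 3.5-fold lower number from compound 1 to compound 3 (0.54 log units; beyond the scatter) and a 2.0-fold lower number from compound 2 to compound 3 (0.30 log units; within the scatter). These show that changing the group at this position moves the number, at most, by a modest amount, and that compound 3 already sits at the low end of that span.

On that basis the step of a 2.0-fold higher number from compound 3 to compound 4 (0.30 log units; within the scatter) is expected to be small, if anything toward a somewhat higher number, since compound 3 holds the lowest value and the measured swaps never went far. Compound 4 is therefore estimated at 0.04 ug/mL in this assay, with a plausible range from 0.015 ug/mL to 0.12 ug/mL.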

Compound 4, half-maximal inhibitory concentration: 0.03 ug/mL
For compound 4 the middle estimate is 1.3-fold (0.12 log units) above the measured one; the range from low to high includes it.
By their numbers in this assay, from the lowest: compounds 3, 4, 2 and 1 (each within the scatter of the next, the first and the last beyond it).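

In this assay, within the data shown here, methyl is the only group on this aromatic carbon that is not a halogen, yet a 1.5-fold higher number from compound 3 to compound 4 (0.18 log units; within the scatter) and a 1.3-fold lower number from compound 2 to compound 4 (0.12 log units; within the scatter) leave it inseparable from bromo and from iodo. Only fluoro can be told apart from methyl, with a 2.3-fold lower number from compound 1 to compound 4 (0.37 log units; beyond the scatter) as the one new step beyond the scatter, so among these compounds a low number at this position does not depend on a halogen, although compound 1 itself remains within the scatter of compound 2. Nothing available here accounts for how closely methyl tracks bromo and iodo.

On these data alone, all four groups sit on the same aromatic carbon, so it remains open whether an amine, a carboxylic acid or a longer chain there would stay within this narrow span or leave it. As far as these compounds go, it also remains open whether methyl and the halogens would stay this close on any other carbon of that ring, or on a different core.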